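From 3-hydroxyazetidin-1-yl to 3-hydroxypyrrolidin-1-yl on the carbonyl carbon

This account rests on a few compounds, and the source may have more. Where it says the series, first, only, none or still open, it means among the compounds named here.

In an in vitro ADME assay on microsomes from liver (Rattus norvegicus) for metabolic stability (on this read-out lower numbers stand for a shorter-lived compound and higher numbers for a longer-lived compound), compound 1 `CC(=O)c1cc(C(=O)NOC(CO)CO)c(Nc2ccc(I)cc2F)n1C` gives 0.267 h and compound 2 `CC(=O)c1cc(C(=O)N2CC(O)C2)c(Nc2ccc(I)cc2F)n1C` gives 0.217 h, so the two lie within the scatter of each other. Compound 3 `CC(=O)c1cc(C(=O)N2CC[C@@H](O)C2)c(Nc2ccc(I)cc2F)n1C` carries 3-hydroxypyrrolidin-1-yl in place of 3-hydroxyazetidin-1-yl on a carbonyl carbon. For the measured compounds named here, the one measured step at this carbonyl carbon, a 1.2-fold lower number from compound 1 to compound 2 (0.09 log units; within the scatter), is a different exchange and stays within the scatter. No change beyond the scatter is therefore expected in this assay, and the expected step is a 1.1-fold higher number from compound 2 to compound 3 (0.03 log units; within the scatter). For compound 3 the estimated half-life is 0.23 h, with an expected range of 0.11 h to 0.47 h.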

Compound 3, half-life: 0.15 h
Estimate against measurement, compound 3: 1.5-fold (0.19 log units) above; the range from low to high includes it.
By their numbers in this assay, from the lowest: compounds 3, 2 and 1 (each within the scatter of the next).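

In this assay the exchange for 3-hydroxypyrrolidin-1-yl gives a 1.4-fold lower number from compound 2 to compound 3 (0.16 log units; within the scatter) and, measured against (2-hydroxy-1-(hydroxymethyl)ethoxy)amino, gives a 1.8-fold lower number from compound 1 to compound 3 (0.25 log units; within the scatter) on the same carbonyl carbon. A five-membered ring on this carbonyl carbon therefore joins the four-membered ring and the (2-hydroxy-1-(hydroxymethyl)ethoxy)amino group within the scatter of one another. Nothing at hand accounts for these numbers. On these data alone, whether the opposite enantiomer of 3-hydroxypyrrolidin-1-yl, a piperazin-1-yl group or a ring bearing a carboxylic acid would move the half-life beyond the scatter remains open.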